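This account rests on a few compounds, and the source may have more. Where it says the series, first, only, none or still open, it means among the compounds named here.

Working notes on a short series built on one shared core. Compound 1 is `CC(=O)OC[C@H]1O[C@@H](SC(=S)C2=C(Nc3ccc(Cl)cc3Cl)CC(C)(C)CC2=O)[C@H](OC(C)=O)[C@@H](OC(C)=O)[C@@H]1OC(C)=O`, compound 2 is `CC(=O)OC[C@H]1O[C@@H](SC(=S)C2=C(Nc3ccc(Cl)cc3)CC(C)(C)CC2=O)[C@H](OC(C)=O)[C@@H](OC(C)=O)[C@@H]1OC(C)=O` and compound 3 is `CC(=O)OC[C@H]1O[C@@H](SC(=S)C2=C(Nc3ccc(Br)cc3)CC(C)(C)CC2=O)[C@H](OC(C)=O)[C@@H](OC(C)=O)[C@@H]1OC(C)=O`. In an ADME assay on CC-1 cells (Rattus norvegicus, strain Wistar) for cytotoxicity, read by MTT assay, with a stated time of 48 h (a higher number here means a weaker inhibitor, a lower number a stronger inhibitor), compound 1 stands as "not determined" (no result reported), so no number is available for it. In this assay compound 2 gives > 20 ug/mL, which is a limit of the assay and not a number. Going by the values given here, the only fixed point for compound 2 is therefore (the limit of > 20 ug/mL in this assay, at which 1 of the 2 values shown sits), and no step between measured compounds exists in this set. Compound 3 differs from compound 2 by bromo in place of chloro on an aromatic carbon, a change confined to one aromatic carbon with nothing else on the core altered. Among the compounds with values here, with no measured step to lean on and a change of this size, the step that the limit leaves unreadable from compound 2 to compound 3 is expected to be none beyond the usual scatter, and the most likely outcome is that compound 3 is again reported only as a limit. For compound 3 the estimated value in this assay is 30 ug/mL, with an expected range from 15 ug/mL to 80 ug/mL.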

Compound 3, half-maximal inhibitory concentration: 19.8 ug/mL
For compound 3 the middle estimate is 1.5-fold (0.18 log units) above the measured one; low and high end bracket the measured number.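

In this assay, going by these compounds alone, compound 3 gives 19.8 ug/mL, the first single number, so the 4-bromophenyl member can be placed on the scale where the 4-chlorophenyl member cannot. Compound 2 gives > 20 ug/mL, which is a limit of the assay and not a number. Bromo in place of chloro on this aromatic carbon, para to a large group, therefore gives a number no higher from compound 2 to compound 3 (the limit leaves the size open), and the step shows no more than that because its starting point is a limit: the limit of > 20 ug/mL in this assay, at which 1 of the 3 values shown sits.

From the compounds shown here alone, compound 1 stands in this assay as "not determined" (no result reported), so the series gives no reading of a second chloro on the ring, and whether compound 3 differs from compound 2 by any real margin stays open. Also open is how this assay responds to a group of another kind on this same aromatic carbon, such as a methoxy group, an amine or a carboxylic acid, since the compounds shown carry only chloro or bromo there.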